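Replacing the aryl group of compound 2

This account rests on a few compounds, and the source may have more. Where it says the series, first, only, none or still open, it means among the compounds named here.

Measured in a functional assay on A549 cells (Homo sapiens) for cytotoxicity, read by MTT assay, with a stated time of 72 h; a lower number here means a stronger inhibitor, a higher number a weaker inhibitor:
- compound 1 `O=C(/C=C/c1ccccc1[N+](=O)[O-])Nc1cc2c(Nc3ccc(F)c(Cl)c3)ncnc2cc1O[C@H]1CCOC1` gives 8820 nM
- compound 2 `COc1cc(/C=C/C(=O)Nc2cc3c(Nc4ccc(F)c(Cl)c4)ncnc3cc2O[C@H]2CCOC2)cc(OC)c1O` gives 27000 nM

Of these two, compound 2 stands highest, at 27000 nM, and is the weaker inhibitor. Compound 3 `O=C(/C=C/c1ccc(F)cc1Cl)Nc1cc2c(Nc3ccc(F)c(Cl)c3)ncnc2cc1O[C@H]1CCOC1` carries 2-chloro-4-fluorophenyl in place of 4-hydroxy-3,5-dimethoxyphenyl on a double-bonded chain carbon bound to a double-bonded chain carbon. For the measured compounds named here, only one measured step bears on this change: a 3.1-fold higher number from compound 1 to compound 2 (0.49 log units; beyond the scatter), modest and beyond the scatter, when 4-hydroxy-3,5-dimethoxyphenyl entered. The same group leaves here, so a step of like size towards a lower number is expected in this assay, namely a 2.5-fold lower number from compound 2 to compound 3 (0.39 log units; beyond the scatter), on this single precedent. The value expected for compound 3 is 11000 nM, within a range of 4000 nM to 27000 nM.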

Compound 3, half-maximal inhibitory concentration: 5190 nM
Estimate against measurement, compound 3: 2.1-fold (0.33 log units) above, within the range that was stated.
By their numbers in this assay, from the lowest: compounds 3 and 1 (each within the scatter of the next); then compound 2.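

In this assay, the exchange of 4-hydroxy-3,5-dimethoxyphenyl for 2-chloro-4-fluorophenyl on this double-bonded chain carbon gives a clear shift (a 5.2-fold lower number from compound 2 to compound 3 (0.72 log units; beyond the scatter)), so two different aryl groups now stand apart from 4-hydroxy-3,5-dimethoxyphenyl. The exchange of 2-nitrophenyl for 2-chloro-4-fluorophenyl does not separate those two groups (a 1.7-fold lower number from compound 1 to compound 3 (0.23 log units; within the scatter)). Nothing measured here accounts for either step.

The compounds shown leave open whether the hydroxy or the methoxy groups of 4-hydroxy-3,5-dimethoxyphenyl go with the higher number. As far as these compounds go, how an aryl group bearing an amine or a carboxylic acid would behave here also stays open.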